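Removing Bulk from the Isopropyl Group of Compound 2

The source may hold more compounds than are shown below. What is called first, only, known or untested is meant among the compounds shown, and "the series" means these compounds.

Compound 1 `Cc1cc(=O)n2nc(SCc3ccc(F)cc3)nc2[nH]1`: > 40000 nM (a limit of the assay)
Compound 2 `Cc1cc(=O)n2nc(SCc3ccc(C(C)C)cc3)nc2[nH]1`: 17300 nM

Among the compounds with values here, in a functional assay on A-431 cells (Homo sapiens) for antiproliferative activity, read by MTT assay, with a stated time of 24 h (a lower number here means a stronger inhibitor, a higher number a weaker inhibitor), compound 2 gives 17300 nM, the only exact number so far. Compound 1 gives only a limit, > 40000 nM. Compound 3 `Cc1ccc(CSc2nc3[nH]c(C)cc(=O)n3n2)cc1` differs from compound 2 as follows: methyl in place of isopropyl on an aromatic carbon. Within the data shown here, the only measured step that bears on this is an at least 2.3-fold lower number from compound 1 to compound 2 (0.36 log units; beyond the scatter), with isopropyl in place of fluoro. From the compounds shown here alone, its true size is unknown, given (the limit of > 40000 nM in this assay, at which 1 of the 2 values shown sits). With isopropyl leaving, a modest step back to a higher number is expected in this assay. The expected change is a 1.7-fold higher number from compound 2 to compound 3 (0.24 log units; within the scatter). Compound 3 is estimated at 30000 nM, within an expected range of 15000 nM to 60000 nM.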

Compound 3, half-maximal inhibitory concentration: 15800 nM
Compound 3: the middle estimate sits 1.9-fold (0.28 log units) above what was measured, and the stated range covers the measured number.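

In this assay the change from isopropyl to methyl gives a 1.1-fold lower number from compound 2 to compound 3 (0.04 log units; within the scatter) and so isopropyl shows no measurable edge over methyl at this position, para to a large group. Replacing fluoro with methyl gives an at least 2.5-fold lower number from compound 1 to compound 3 (0.40 log units; beyond the scatter) and so methyl, like isopropyl, stands apart from fluoro here. That step has no exact size, since compound 1 gives only a limit: the limit of > 40000 nM in this assay, at which 1 of the 3 values shown sits.

Still open, from the compounds shown here alone, is how an amine, a carboxylic acid or a longer chain at this position would compare with methyl and isopropyl.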